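Replacing phenylcarbamoyl on compound 1

The source may report more compounds than this note shows. Statements on the series, on what has been measured and on what is new or still open speak of the compounds shown alone.

Compound 1 `O=C(Nc1ccccc1)c1cnc(NCc2c(F)ccc3c2CCO3)n2cnnc12` was tested in a physicochemical assay for solubility, read by LC-MS, in phosphate buffer, with a stated time of 24 h, at pH 7.4; on this read-out higher numbers stand for higher solubility and lower numbers for lower solubility. On these data alone, there compound 1 gives < 1000 nM, which is a limit of the assay and not a number, so its true position on the scale stays unknown. Compound 2 `Cc1ncccc1-c1cnc(NCc2c(F)ccc3c2CCO3)c2nn(CC#N)c(=O)n12`, which differs in several places, gives a real reading of 4000 nM in this assay. The next compound to be tested is compound 3 `CN(c1ncco1)c1cnc(NCc2c(F)ccc3c2CCO3)n2cnnc12`, with methyl(1,3-oxazol-2-yl)amino in place of phenylcarbamoyl on an aromatic carbon. Going by the values given here, no measured pair shows this swap, so any forecast is rough. Among the compounds with values here, the only numerical guide is compound 2 at 4000 nM, and a modest rise seems the likelier direction. The expected change is an at least 1.5-fold higher number from compound 1 to compound 3 (0.17 log units; that floor lies within the scatter), and this assay may again return only a limit. For compound 3 the estimated value is 1500 nM, with an expected range from 400 nM to 6000 nM.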

Compound 3, solubility: 67000 nM
Compound 3: the middle estimate sits 45-fold (1.65 log units) below what was measured, outside the stated range (above it).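

At this position on the shared core, an aromatic carbon of the six-membered ring with 2 nitrogen, methyl(1,3-oxazol-2-yl)amino in place of phenylcarbamoyl gives an at least 67-fold higher number from compound 1 to compound 3 (1.82 log units; beyond the scatter) in this assay. That shows the group at this one place can move the read-out a long way, which compound 2, differing in several places, could not show. The size printed is a floor and not an exact figure because compound 1 stands at a limit of the assay and not at a number: the limit of < 1000 nM in this assay, at which 1 of the 3 values shown sits.

The swap also exchanges a six-membered carbon ring for a five-membered aromatic ring and removes the hydrogen-bond donor, and this one pair cannot separate those changes. On these data alone, whether the ring is needed at all, or whether a dimethylamino group or a morpholine ring on the same carbon would read alike, stays open.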